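The compounds below may be only part of what the source reports. "The series", "measured", "known", "first", "only" and "open" are said of these compounds alone.

Measured compounds:
compound 1 `CN1CCN(CCCC(=O)OC2CC3(N4CCCCC4)CC(c4ccccc4)C2C(c2ccccc2)C3)CC1` gives 22300 nM;
compound 2 `CN1CCN(CCCN2CCC3(N4CCCCC4)CC(c4ccccc4)C2C(c2ccccc2)C3)CC1` gives 62500 nM;
compound 3 `CN1CCN(CCCC(=O)OC2CC3(N4CCCC4)CC(c4ccccc4)C2C(c2ccccc2)C3)CC1` gives 10200 nM.

All three were tested in an ADME assay on L6 cells (Rattus norvegicus) for cytotoxicity; on this read-out higher numbers stand for weaker inhibition and lower numbers for stronger inhibition. Compound 2 has the highest number of the three; the difference between its core and that of compound 1 is not broken down here, so the two values are simply taken as they stand. Compound 3 differs from compound 1 by one change, (pyrrolidin-1-yl in place of piperidin-1-yl on a saturated ring carbon), and that change gave a 2.2-fold lower number from compound 1 to compound 3 (0.34 log units; beyond the scatter).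

Compound 4 `CN1CCN(CCCN2CCC3(N4CCCC4)CC(c4ccccc4)C2C(c2ccccc2)C3)CC1` has not yet been measured. It differs from compound 2 by pyrrolidin-1-yl in place of piperidin-1-yl on a saturated ring carbon. Within the data shown here, this is the same kind of change as the one from compound 1 to compound 3, though the surroundings are not identical: around the place in compound 1 there are also two ring bonds from the ring atom that bears a large group, which is not said of compound 2. A step of about the same size is expected, a 2.1-fold lower number from compound 2 to compound 4 (0.32 log units; beyond the scatter), resting on the step seen from compound 1 to compound 3, a 2.2-fold lower number from compound 1 to compound 3 (0.34 log units; beyond the scatter), and on the starting number of compound 2, 62500 nM. On that basis compound 4 is estimated at 30000 nM, with a likely range from 12000 nM to 70000 nM.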

Compound 4, half-maximal inhibitory concentration: 27500 nM
Beside the measured number, compound 4's estimate is 1.1-fold (0.04 log units) above it, within the range that was stated.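

Putting pyrrolidin-1-yl in place of piperidin-1-yl on a saturated ring carbon gave a 2.3-fold lower number from compound 2 to compound 4 (0.36 log units; beyond the scatter) in this assay, and the two cores responded to this change by about the same amount: the same change on two cores in this assay, a 2.2-fold lower number (0.34 log units; beyond the scatter) from compound 1 to compound 3 and a 2.3-fold lower number (0.36 log units; beyond the scatter) from compound 2 to compound 4, 1.0-fold (0.02 log units) apart, within the scatter of two such steps

Within these four compounds, the step measured on one core would therefore have served as a fair guide to the step on the other, and the gap between the cores did not alter its size. Still, this rests on just two pairs of compounds, so it does not show that the step would hold on a further core, and it does not explain why the change lowers the number.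

The compounds shown leave open whether another amine on that carbon, such as morpholin-4-yl or dimethylamino, would shift the number further or reverse the step. They also leave open whether the same step would appear with a longer chain leading to the methylated ring.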